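Chain extension from compound 3 to compound 4

The compounds below may be only part of what the source reports. "The series", "measured", "known", "first", "only" and "open" are said of these compounds alone.

- compound 1 `CCCCCC(CCO)n1cnc2c(N)ncnc21`: > 50000 nM (a limit)
- compound 2 `CCCCCCCC(CCO)n1cnc2c(OC)ncnc21`: 23900 nM
- compound 3 `CCCCCCCC(CCO)n1cnc2c(N)ncnc21`: > 50000 nM (a limit)

In a functional assay on SW480 cells (Homo sapiens) for antiproliferative activity, read by MTT assay, with a stated time of 48 h (on this read-out higher numbers stand for weaker inhibition and lower numbers for stronger inhibition), compound 3 stands only at a limit, > 50000 nM. Compound 1 is also known only as a limit, > 50000 nM. The series is thus dominated by the limit of > 50000 nM in this assay, at which 2 of the 3 values shown sit. Only compound 2 gives a true number, 23900 nM.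

Compound 4 `CCCCCCCCCC(CCO)n1cnc2c(N)ncnc21` keeps the amino group of compound 3 and differs in the chain: ethyl in place of hydrogen on a saturated chain carbon, eight bonds along the chain from an aromatic nitrogen.

Going by the values given here, two measured steps bear on this. Among the compounds with values here, the one chain change, a step that the two limits leave unreadable from compound 1 to compound 3, cannot be sized. The other, an at least 2.0-fold higher number from compound 2 to compound 3 (0.32 log units; beyond the scatter), is amino in place of methoxy on an aromatic carbon, a different change from the one at issue here. Neither supports a firm direction, so no step beyond the scatter is expected, although a number somewhat under the limit remains possible.

Compound 4 is expected at about 45000 nM, with an estimated range of 18000 nM to 90000 nM. The expected step is an at least 1.1-fold lower number from compound 3 to compound 4 (0.04 log units; that floor lies within the scatter).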

Compound 4, half-maximal inhibitory concentration: 6030 nM
Compound 4: the middle estimate sits 7.5-fold (0.87 log units) above what was measured; the measured number lies below the stated range.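

In this assay, going by these compounds alone, the amino compounds now give a true number for the first time. Extending the chain at this carbon gives an at least 8.2-fold lower number from compound 3 to compound 4 (0.91 log units; beyond the scatter), and the longer step on the same chain gives an at least 8.2-fold lower number from compound 1 to compound 4 (0.91 log units; beyond the scatter), so chain length at this position matters with the amino group kept, which the unreadable step between the two earlier amino compounds could not show. Both steps are floors and not sizes, because their starting compounds sit at a limit: the limit of > 50000 nM in this assay, at which 2 of the 4 values shown sit.

Still open, as far as these compounds go, is whether a longer chain than that of compound 4 carries the gain further or reverses it. Also open, from the compounds shown here alone, are whether methoxy in place of amino changes the number on this chain as it does on the chain of compound 3, and whether an amine can stand in place of the hydroxyl.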